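The source may hold more compounds than are shown below. What is called first, only, known or untested is meant among the compounds shown, and "the series" means these compounds.

Of the compounds shown here, two that share one core have been tested in an ADME assay on A549 cells (Homo sapiens) for cytotoxicity, read by CellTiter-Glo; a lower number here means that less compound is tolerated, a higher number that more compound is tolerated. Compound 1 `Cc1c(Cc2ccccc2)c(=O)oc2cc(OCC(O)CNCCCCCCO)ccc12` gives 40300 nM. Compound 2 `Cc1c(Cc2ccc(C(C)(C)C)cc2)c(=O)oc2cc(OCC(O)CN3CCC(C(N)=O)CC3)ccc12` gives 14700 nM, the lowest of the two numbers, and its gap to compound 1 lies beyond the usual scatter. Compound 3 `Cc1c(Cc2ccc(-c3ccc(C=O)c(F)c3)cc2)c(=O)oc2cc(OCC(O)CN3CCC(C(N)=O)CC3)ccc12` differs from compound 2 in a single place: 3-fluoro-4-formylphenyl in place of tert-butyl on an aromatic carbon. Within the data shown here, no pair of measured compounds shows what such a change does, so the expectation rests on compound 2 alone. The estimate for compound 3 is 10000 nM, with a range from 4000 nM to 25000 nM. The expected step, a 1.5-fold lower number from compound 2 to compound 3 (0.17 log units; within the scatter), points to a somewhat lower number, within the scatter.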

Compound 3, half-maximal cytotoxic concentration: 62400 nM
The estimate for compound 3 lay 6.2-fold (0.80 log units) below the measured number; the measured number lies above the stated range.
By their numbers in this assay, from the lowest: compound 2; then compounds 1 and 3 (each within the scatter of the next).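

In this assay, 3-fluoro-4-formylphenyl in place of tert-butyl on this aromatic carbon gives a 4.2-fold higher number from compound 2 to compound 3 (0.63 log units; beyond the scatter) and so shows that the group at this position can shift the tolerated concentration beyond the scatter. The larger group, with its added aromatic ring, does not lower the number here. This single step changes the ring, the fluorine and the formyl together, so it cannot show which of them matters. On these data alone, whether a plain phenyl, or a carboxylic acid in place of the formyl, would behave the same stays open. No measurement here explains the rise.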